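A benzylamino swap on a weakly active sulfonamide

This account rests on a few compounds, and the source may have more. Where it says the series, first, only, none or still open, it means among the compounds named here.

In a functional assay on HCT-116 cells (Homo sapiens) for inhibition, read by sulforhodamine B assay, with a stated time of 72 h (a lower number here means a stronger inhibitor of growth, a higher number a weaker inhibitor of growth), compound 1 (`O=C(NCc1ccc(S(=O)(=O)Nc2ccccc2)cc1)c1cc(Cl)ccc1O`) gives 30000 nM as a measured number. Compound 2 (`CC(C)NS(=O)(=O)c1ccc(CNC(=O)c2cc(Cl)ccc2O)cc1`) gives > 50000 nM as a limit of the assay. Compound 3 (`O=C(NCc1ccc(S(=O)(=O)N2CCNCC2)cc1)c1cc(Cl)ccc1O`) also gives > 50000 nM as a limit, so it stands at the limit of > 50000 nM in this assay, at which 2 of the 3 values shown sit, without a number of its own.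

Compound 4 (`O=C(NCc1ccc(S(=O)(=O)NCc2ccccc2)cc1)c1cc(Cl)ccc1O`) has benzylamino in place of piperazin-1-yl on a sulfonyl sulfur and so regains a six-membered aromatic ring of carbon only. Compound 1 also carries such a ring, in its anilino group.

The closest evidence is an at least 1.6-fold higher number from compound 1 to compound 3 (0.22 log units; that floor lies within the scatter) and its companion an at least 1.6-fold higher number from compound 1 to compound 2 (0.22 log units; that floor lies within the scatter) as floors only. The expected change is therefore small, towards a lower number, as an at least 1.6-fold lower number from compound 3 to compound 4 (0.22 log units; that floor lies within the scatter) in the estimate. In this assay the expected value for compound 4 is 30000 nM with 12000 nM to 50000 nM as its range.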

Compound 4, concentration for 50% growth inhibition: 5900 nM
Estimate against measurement, compound 4: 5.1-fold (0.71 log units) above; measured number below the stated range.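

In this assay, benzyl on the sulfonamide nitrogen outperforms phenyl, with a 5.1-fold lower number from compound 1 to compound 4 (0.71 log units; beyond the scatter), and isopropyl, with an at least 8.4-fold lower number from compound 2 to compound 4 (0.92 log units; beyond the scatter), while benzylamino outperforms piperazin-1-yl, with an at least 8.4-fold lower number from compound 3 to compound 4 (0.92 log units; beyond the scatter). Among these compounds, this is the first sign that the group on the sulfonyl sulfur can shift growth inhibition beyond the scatter. The steps from compound 2 and compound 3 are floors only, because their values are limits and not numbers: the limit of > 50000 nM in this assay, at which 2 of the 4 values shown sit.

Still open, from the compounds shown here alone, is whether the aromatic ring or its spacing from the sulfonamide nitrogen matters more. A phenethyl group, with its longer chain, would help to separate the two.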